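Benzyl for cycloheptyl on the urea nitrogen: two cores

The compounds below may be only part of what the source reports. "The series", "measured", "known", "first", "only" and "open" are said of these compounds alone.

Measured compounds in a functional assay on a cell-free system (plasma) with sterol O-acyltransferase, Soat (Rattus norvegicus) as the target; a lower number here means that less compound is needed, a higher number that more compound is needed for the effect:
- compound 1, `O=C(Nc1c(F)cc(F)cc1F)N(Cc1cccc(-c2cc[nH]n2)c1)C1CCCCCC1`, gives 0.062 mg/kg
- compound 2, `O=C(Nc1c(F)cc(F)cc1F)N(Cc1ccccc1)Cc1cccc(-c2cc[nH]n2)c1`, gives 0.096 mg/kg
- compound 3, `CSc1cc(C)nc(SC)c1NC(=O)N(Cc1cccc(-c2cnn(C)c2)c1)C1CCCCCC1`, gives only a limit, > 0.1 mg/kg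

The value of compound 3 is a limit of this assay and not a number; compound 3 sits at the limit of > 0.1 mg/kg in this assay, at which 1 of the 3 values shown sits.

Compounds 1 and 2 share a core and differ in one place: benzyl in place of cycloheptyl on an amide-type nitrogen. The step is a 1.5-fold higher number from compound 1 to compound 2 (0.19 log units; within the scatter). Compounds 3 and 1 differ in more than one place; the difference between the two cores is not broken down here.

Compound 4, `CSc1cc(C)nc(SC)c1NC(=O)N(Cc1ccccc1)Cc1cccc(-c2cnn(C)c2)c1`, is not yet measured. It arises from compound 3 by benzyl in place of cycloheptyl on an amide-type nitrogen, the same change as from compound 1 to compound 2, at a place described in the same words.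

For the measured compounds named here, the expectation for compound 4 rests on the one measured instance of this change. The step from compound 1 to compound 2 lay within the scatter, so a step of about the same size is expected for compound 4, a step that the limit leaves unreadable from compound 3 to compound 4. Since compound 3 sits at the limit, compound 4 is expected to stay near or beyond that limit, with an estimate of 0.2 mg/kg in this assay and a likely range from 0.1 mg/kg to 0.6 mg/kg. The chance that this assay again reports only a limit for compound 4 is judged high.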

Compound 4, dose for half-maximal effect: > 0.1 mg/kg
Compound 4 was reported as a limit; the forecaster's own chance of this, stated with the estimate: 70%; the middle value lies beyond the limit too.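

In this assay compound 4 gives > 0.1 mg/kg, which is a limit of the assay and not a number. Compound 3 is also reported only as a limit, so no step can be read between compound 3 and compound 4: the limit of > 0.1 mg/kg in this assay, at which 2 of the 4 values shown sit.

Still open, going by these compounds, is whether benzyl in place of cycloheptyl has the same effect on the core of compound 3 as on the core of compound 1.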